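The compounds below may be only part of what the source reports. "The series", "measured", "known", "first", "only" and "open" are said of these compounds alone.

Compound 1 (`Nc1cccc(Nc2c(C(=O)NCc3ccc(F)cc3)nc(Br)c3cccnc23)c1`): > 10000 nM (a limit of the assay)
Compound 2 (`N[C@H]1CC[C@H](Nc2c(C(=O)NCc3ccco3)nc(Br)c3cccnc23)CC1`): 10000 nM

Going by the values given here, in a functional assay on SK-BR-3 cells (Homo sapiens) for cytotoxicity, read by MTT assay, with a stated time of 72 h (on this read-out higher numbers stand for weaker inhibition and lower numbers for stronger inhibition), compound 2 gives 10000 nM as the only actual number so far. Compound 1 gives > 10000 nM as a limit and not a number. Compound 3 (`COc1cccc(CNC(=O)c2nc(Br)c3cccnc3c2N[C@H]2CC[C@H](N)CC2)c1`) has not yet been measured. It matches compound 2 except for one change, with 3-methoxyphenyl in place of furan-2-yl on a saturated chain carbon bound to an amide-type nitrogen. Among the compounds with values here, no measured pair shows what such a change does, so the expectation rests on compound 2 alone. Nothing beyond the scatter is expected in this assay, and any shift would lean slightly towards stronger inhibition. The expected outcome is a 1.7-fold lower number from compound 2 to compound 3 (0.22 log units; within the scatter) as a small step. For compound 3 the estimated value is 6000 nM (expected range 1500 nM to 20000 nM).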

Compound 3, half-maximal inhibitory concentration: 6000 nM
Estimate against measurement, compound 3: no gap at the digits printed; the range from low to high includes it.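

In this assay, the change to 3-methoxyphenyl from furan-2-yl on a saturated chain carbon bound to an amide-type nitrogen gives a 1.7-fold lower number from compound 2 to compound 3 (0.22 log units; within the scatter), so this pair does not separate the two groups. Going by these compounds alone, it is the first measured pair at this position, and it shows that a six-membered aromatic ring of carbon only, with 8 heavy atoms, can stand in place of a five-membered aromatic ring with 1 hetero atom and 5 heavy atoms without a shift beyond the scatter. Compound 1 stands at a limit and not at a number: the limit of > 10000 nM in this assay, at which 1 of the 3 values shown sits.

As far as these compounds go, whether any group at this position can move the value beyond the scatter remains open. The compounds shown do not tell what a carboxylic acid on the ring or a longer chain in this place would do.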